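Swapping nitro for chloro on a triazole-linked benzothiazole cytotoxicity probe

This account rests on a few compounds, and the source may have more. Where it says the series, first, only, none or still open, it means among the compounds named here.

Compound 2 `O=[N+]([O-])c1ccc(-c2nnc(-c3cccnc3)n2Nc2nc3cc(Cl)c(Cl)cc3s2)cc1` is tested in an ADME assay on MT4 cells (Homo sapiens) for cytotoxicity, read by MTT assay, with a stated time of 5 days (on this read-out lower numbers stand for higher toxicity in this test and higher numbers for lower toxicity in this test), where compound 2 gives 68.7 ug/mL. Its companion compound 1 `O=[N+]([O-])c1ccc(-c2nnc(-c3cccnc3)n2Nc2nc3ccc(Cl)cc3s2)cc1` gives 53.7 ug/mL, and the two values lie within the scatter of each other, as the step of a 1.3-fold higher number from compound 1 to compound 2 (0.11 log units; within the scatter) shows. Compound 3 `Clc1ccc(-c2nnc(-c3cccnc3)n2Nc2nc3cc(Cl)c(Cl)cc3s2)cc1` differs from compound 2 by chloro in place of nitro on an aromatic carbon. For the measured compounds named here, no measured step mirrors this change; the only known step concerns a different substitution and was small. The step of a 1.2-fold lower number from compound 2 to compound 3 (0.10 log units; within the scatter) is therefore expected to stay within the scatter. Compound 3 is estimated at 55 ug/mL, with a range from 25 ug/mL to 115 ug/mL.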

Compound 3, half-maximal cytotoxic concentration: 52.1 ug/mL
Compound 3: middle estimate off by 1.1-fold (0.02 log units), on the high side; measured number inside the range.
By their numbers in this assay, from the lowest: compounds 3, 1 and 2 (each within the scatter of the next).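

In this assay, moving from 4-nitrophenyl to 4-chlorophenyl gives a 1.3-fold lower number from compound 2 to compound 3 (0.12 log units; within the scatter) and so stays within the scatter. At this place on the ring, then, chloro can stand in for nitro without a readable shift in the number, whereas the earlier step concerned chloro at a different place in the molecule. No measured information explains this result.

As far as these compounds go, it remains open whether an amine or a carboxylic acid at this place would also stay within the scatter. Also open, from the compounds shown here alone, is whether this holds on the core of compound 1.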